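Compound 3 to compound 4: nitro in place of methoxy

The source may hold more compounds than are shown below. What is called first, only, known or untested is meant among the compounds shown, and "the series" means these compounds.

Measured in a functional assay on KMS-11 cells (Homo sapiens) for antiproliferative activity, read by CellTiter-Glo, with a stated time of 72 h; a higher number here means a weaker inhibitor, a lower number a stronger inhibitor:

Compound 1 `COc1ccc(C(=O)N(Cc2ccncc2)Cc2cccc(OCC3CCCCC3)c2)cc1`: 19700 nM
Compound 2 `COc1ccc(C(=O)N(Cc2ccncc2)Cc2cccc(OCCc3ccc(Br)cc3)c2)cc1`: 8400 nM
Compound 3 `COc1ccc(C(=O)N(Cc2ccncc2)Cc2cccc(OCc3cccc(OC)c3)c2)cc1`: 16900 nM

Compound 3, at 16900 nM, lies within the scatter of both other compounds, as a 1.2-fold lower number from compound 1 to compound 3 (0.07 log units; within the scatter) and a 2.0-fold higher number from compound 2 to compound 3 (0.30 log units; within the scatter) show. Only a 2.3-fold lower number from compound 1 to compound 2 (0.37 log units; beyond the scatter) goes beyond the scatter, and that step is modest.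

The next compound is compound 4 `COc1ccc(C(=O)N(Cc2ccncc2)Cc2cccc(OCc3cccc([N+](=O)[O-])c3)c2)cc1`, which carries nitro in place of methoxy on an aromatic carbon, meta to a large group: nitro in place of methoxy on an aromatic carbon. The 3-methoxyphenyl group thus becomes 3-nitrophenyl.

For the measured compounds named here, no measured step makes this exact change. All three steps instead exchange the whole group on a saturated chain carbon bound to an oxygen on an aromatic ring, so they bear on it only indirectly. Even these larger exchanges moved the number little, and the data give no sign of how nitro itself behaves. A large move is therefore not expected, and no change beyond the scatter is the expectation. The expected step in this assay is a 1.3-fold lower number from compound 3 to compound 4 (0.11 log units; within the scatter). For compound 4 the estimated value is 13000 nM, with an expected range from 5500 nM to 30000 nM.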

Compound 4, half-maximal inhibitory concentration: 19600 nM
Compound 4: the middle estimate sits 1.5-fold (0.18 log units) below what was measured; the range from low to high includes it.
By their numbers in this assay, from the lowest: compounds 2, 3, 4 and 1 (each within the scatter of the next, the first and the last beyond it).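

In this assay, for the compounds shown here, the exchange on the aromatic carbon meta to a large group gives the first direct reading at this position (a 1.2-fold higher number from compound 3 to compound 4 (0.06 log units; within the scatter)): nitro in place of methoxy, with more heavy atoms and one more hydrogen-bond acceptor, leaves the number within the scatter. The 3-nitrobenzyl compound also stands level with the cyclohexyl-bearing compound (a 1.0-fold lower number from compound 1 to compound 4 (0.00 log units; within the scatter)), yet the 4-bromobenzyl group keeps a modest separation beyond the scatter from it (a 2.3-fold higher number from compound 2 to compound 4 (0.37 log units; beyond the scatter)), the same separation seen earlier between the bromo and cyclohexyl compounds, while compound 3 remains within the scatter of all three others. So two quite different substituents at this one place give values that cannot be told apart in this cell assay, and nothing measured here accounts for that.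

As far as these compounds go, whether an amine, a carboxylic acid or a halogen such as fluorine in the place of methoxy on this ring would move the number beyond the scatter stays open. So does whether a longer chain between the oxygen and this ring, or a change in the shared core itself, could reach values well away from those of these four compounds.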